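Alkoxy terminus variation in an arylpiperazine series

The compounds below may be only part of what the source reports. "The series", "measured", "known", "first", "only" and "open" are said of these compounds alone.

Measured so far:
compound 1, `COc1ccccc1N1CCN(CCCNc2ncccc2C(=O)N(C)C)CC1`, 20 nM
compound 2, `CN(C)C(=O)c1cccnc1NCCCN1CCN(c2ccccc2OCC2CC2)CC1`, 10 nM

In a functional assay on aorta for antagonist activity at Alpha-1D adrenergic receptor (Rattus norvegicus) (a higher number here means weaker binding, a lower number tighter binding), compound 1 gives 20 nM and compound 2 gives 10 nM. Compound 2 has the lower of the two numbers, but the step of a 2.0-fold lower number from compound 1 to compound 2 (0.30 log units; within the scatter) lies within the scatter, so the two compounds cannot be ordered on these data.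

Compound 3, `CN(C)C(=O)c1cccnc1NCCCN1CCN(c2ccccc2OCC(C)(C)C)CC1`, is not yet measured. It differs from compound 2 by tert-butyl in place of cyclopropyl on a saturated chain carbon bound to an oxygen on an aromatic ring. Among the measured compounds shown here, the only measured step that touches this position is the one from compound 1 to compound 2, in which a cyclopropyl entered on the same saturated chain carbon bound to an oxygen on the aromatic ring; that step, a 2.0-fold lower number from compound 1 to compound 2 (0.30 log units; within the scatter), stayed within the scatter. Nothing measured separates a ring from an open chain at this position, so the exchange of cyclopropyl for tert-butyl is expected to move the number little, if at all, beyond the scatter.

Compound 3 is therefore expected to give about 12 nM in this assay, within 4 nM to 40 nM. The step this estimate means, a 1.2-fold higher number from compound 2 to compound 3 (0.08 log units; within the scatter), is expected to be small.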

Compound 3, dissociation constant: 50.1 nM
Estimate against measurement, compound 3: 4.2-fold (0.62 log units) below, outside the stated range (above it).
By their numbers in this assay, from the lowest: compounds 2 and 1 (each within the scatter of the next); then compound 3.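

In this assay, the place on a saturated chain carbon bound to an oxygen on an aromatic ring proves sensitive to which group it carries: tert-butyl in place of cyclopropyl gives a 5.0-fold higher number from compound 2 to compound 3 (0.70 log units; beyond the scatter), a step beyond the scatter, so the two groups cannot be treated as interchangeable here. Against hydrogen, tert-butyl also gives a step beyond the scatter, a 2.5-fold higher number from compound 1 to compound 3 (0.40 log units; beyond the scatter), whereas cyclopropyl gave a 2.0-fold lower number from compound 1 to compound 2 (0.30 log units; within the scatter), which stayed within it, so the series now shows that this place tolerates cyclopropyl and hydrogen alike on these numbers but not tert-butyl. No available evidence bears on what lies behind this difference.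

The compounds shown do not tell whether the step from cyclopropylmethyl to neopentyl follows the loss of the ring or the arrival of the branched tert-butyl, a question that isopropyl or cyclobutyl at the same place would address. As far as these compounds go, whether a longer straight chain or an amine at this place would stay with compound 2 or fall with compound 3 also remains open.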